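The compounds below may be only part of what the source reports. "The series", "measured", "known", "first", "only" and "open" are said of these compounds alone.

Three ureas built on a shared core have been measured in a functional assay for antagonist activity at transient receptor potential cation channel subfamily V member 1 (Homo sapiens), read by calcium flux; a lower number here means a stronger inhibitor, a higher number a weaker inhibitor. Compound 1 `O=C(NCc1ccc(N2CCCCCC2)cc1)Nc1cccc2cnccc12` gives 3.3 nM. Compound 2 `O=C(NCc1ccc(N2CCCCCCC2)cc1)Nc1cccc2cnccc12` gives 4.7 nM, and a 1.4-fold higher number from compound 1 to compound 2 (0.15 log units; within the scatter). Compound 3 `CC1CN(c2ccc(CNC(=O)Nc3cccc4cnccc34)cc2)CC(C)O1` gives 258 nM; a 78-fold higher number from compound 1 to compound 3 (1.89 log units; beyond the scatter) and a 55-fold higher number from compound 2 to compound 3 (1.74 log units; beyond the scatter). Compound 1 thus stands with compound 2 inside the scatter and far from compound 3.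

Compound 4 `Cc1cc2c(NC(=O)NCc3ccc(N4CCCCCC4)cc3)cccc2cn1` differs from compound 1 by methyl in place of hydrogen on an aromatic carbon. Among the measured compounds shown here, none of the measured steps touches this part of the core; all three vary the ring on the benzylic aryl, so no measured step bears directly on it. With no basis for a large shift, the step of a 1.2-fold higher number from compound 1 to compound 4 (0.08 log units; within the scatter) is expected to stay within the scatter. Compound 4 is therefore estimated at 4 nM, with a range from 1.5 nM to 15 nM.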

Compound 4, half-maximal inhibitory concentration: 3.8 nM
The estimate for compound 4 lay 1.1-fold (0.02 log units) above the measured number, and the stated range covers the measured number.
By their numbers in this assay, from the lowest: compounds 1, 4 and 2 (each within the scatter of the next); then compound 3.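

Among the compounds shown here, the earlier steps all left the shared core untouched, so this is the first view of a change there. In this assay, methyl in place of hydrogen on an aromatic carbon next to the ring nitrogen gives a 1.2-fold higher number from compound 1 to compound 4 (0.06 log units; within the scatter) and so leaves the number where it was, showing that this position takes a methyl without a shift beyond the scatter. Nothing measured here explains this result. As far as these compounds go, whether ethyl, methoxy or an amine at this position would hold the number as well remains open. So does whether the methyl would have the same effect on compound 2 or compound 3.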